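This account rests on a few compounds, and the source may have more. Where it says the series, first, only, none or still open, it means among the compounds named here.

Compound 1 `N#CC1=C(N)Oc2c(c3nc4ccccc4nc3c3ccccc23)C12C(=O)N(Cc1cnnn1-c1ccc(Cl)cc1)c1ccccc12` carries a 4-chlorophenyl group on an aromatic nitrogen of its triazole ring. In an ADME assay on L02 cells (Homo sapiens) for antiproliferative activity, read by MTT assay, with a stated time of 48 h (on this read-out lower numbers stand for stronger inhibition and higher numbers for weaker inhibition), compound 1 gives > 50000 nM, which is a limit of the assay rather than a number. For the measured compounds named here, only one other compound was measured beside it, compound 2 `N#CC1=C(N)Oc2c(c3nc4ccccc4nc3c3ccccc23)C12C(=O)N(Cc1cnnn1-c1ccccc1Br)c1ccccc12`, which differs in bearing a 2-bromophenyl in place of the 4-chlorophenyl on that aromatic nitrogen. In this assay compound 2 gives > 50000 nM, again a limit and not a number. Going by the values given here, the step that the two limits leave unreadable from compound 1 to compound 2 therefore cannot be sized, and the only evidence available is the limit of > 50000 nM in this assay, at which 2 of the 2 values shown sit.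

Compound 3 `N#CC1=C(N)Oc2c(c3nc4ccccc4nc3c3ccccc23)C12C(=O)N(Cc1cnnn1-c1cccc(Br)c1)c1ccccc12` is not yet measured. It differs from compound 1 by 3-bromophenyl in place of 4-chlorophenyl on an aromatic nitrogen. Because the limit of > 50000 nM in this assay, at which 2 of the 2 values shown sit, shows both measured compounds sitting at the same limit, and because a step that the two limits leave unreadable from compound 1 to compound 2 gives no readable size for a change of the same kind at this aromatic nitrogen, compound 3 is expected to sit at that limit too rather than move beyond the scatter. Its expected step is a step that the limit leaves unreadable from compound 1 to compound 3. In this assay compound 3 is estimated at 80000 nM, with a range from 30000 nM to 300000 nM.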

Compound 3, half-maximal inhibitory concentration: > 50000 nM
Compound 3: only a limit was reported (the forecaster's own chance of this, stated with the estimate: 85%); the middle value lies beyond the limit too.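

In this assay compound 3 gives > 50000 nM, which is a limit and not a number. The steps to compound 3 from compound 1 and from compound 2 therefore cannot be read. The compounds shown leave open whether any group on that aromatic nitrogen would give a readable number in this assay: the limit of > 50000 nM in this assay, at which 3 of the 3 values shown sit.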